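Para-substituted phenyl on the oxazole ketone core

The compounds below may be only part of what the source reports. "The series", "measured", "known", "first", "only" and "open" are said of these compounds alone.

Measured so far:
compound 1, `N#Cc1ccccc1-c1cnc(C(=O)CCCCCCc2ccccc2)o1`: 130 nM
compound 2, `Nc1ccc(-c2cnc(C(=O)CCCCCCc3ccccc3)o2)cc1`: 90 nM

In an assay (Rattus norvegicus) for inhibition of Fatty-acid amide hydrolase 1 (Homo sapiens) (a lower number here means a stronger inhibitor, a higher number a weaker inhibitor), compound 1 gives 130 nM, and compound 2 gives 90 nM; the step of a 1.4-fold lower number from compound 1 to compound 2 (0.16 log units; within the scatter) places the two alongside each other. Compound 3, `NC(=O)c1ccc(-c2cnc(C(=O)CCCCCCc3ccccc3)o2)cc1`, has not been measured. It differs from compound 1 as follows: 4-carbamoylphenyl in place of 2-cyanophenyl on an aromatic carbon. Going by the values given here, the only step available, from compound 1 to compound 2, swaps the same 2-cyanophenyl for another substituted phenyl and stays within the scatter, so no shift beyond the scatter is expected here either. Compound 3 is estimated at 110 nM, between 40 nM and 300 nM, a step of a 1.2-fold lower number from compound 1 to compound 3 (0.07 log units; within the scatter).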

Compound 3, inhibition constant: 10 nM
Compound 3: middle estimate off by 11-fold (1.04 log units), on the high side; the whole stated range lies above it.
By their numbers in this assay, from the lowest: compound 3; then compounds 2 and 1 (each within the scatter of the next).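

In this assay, the group on this aromatic carbon can move the number well beyond the scatter, which the earlier pair did not show (a step of a 13-fold lower number from compound 1 to compound 3 (1.11 log units; beyond the scatter)). With the 4-substituted phenyl kept, carbamoyl in place of amino still matters (a step of a 9.0-fold lower number from compound 2 to compound 3 (0.95 log units; beyond the scatter)), so the 4-substituted phenyl alone does not account for the low number of compound 3. The data shown offer no evidence on why this is so. As far as these compounds go, whether a carboxylic acid or a methyl ester at the same ring carbon would match carbamoyl remains open, as does whether 2-carbamoylphenyl would do so.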